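Sulfanyl linker and dichlorophenyl in place of nitrophenoxy

The compounds below may be only part of what the source reports. "The series", "measured", "known", "first", "only" and "open" are said of these compounds alone.

In an assay on HEK293 cells for displacement of a labelled ligand from Melanocortin receptor 4 (Homo sapiens) (on this read-out higher numbers stand for weaker inhibition and lower numbers for stronger inhibition), compound 1 `CC(C)C[C@H](N)c1cc(C(F)(F)F)ccc1N1CCN(C(=O)COc2ccc([N+](=O)[O-])cc2)CC1` gives 3100 nM, the highest of the three numbers measured. Compound 3 `CC(C)C[C@H](N)c1ccccc1N1CCN(C(=O)[C@H](C)Cc2ccc(Cl)cc2Cl)CC1` stands nearest, and in this assay compound 3 gives 16 nM. Compound 2 `COc1cc(Cl)ccc1CC(C)C(=O)N1CCN(c2ccc(Cl)cc2[C@@H](N)CC(C)C)CC1` lies furthest away, and in this assay compound 2 gives 9.1 nM. Both gaps lie beyond the scatter, so compound 1 is clearly the weakest of the three.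

Compound 4 `CC(C)C[C@H](N)c1cc(C(F)(F)F)ccc1N1CCN(C(=O)CSc2ccc(Cl)cc2Cl)CC1` has not yet been measured. It differs from compound 1 in one place: (2,4-dichlorophenyl)sulfanyl in place of 4-nitrophenoxy on a saturated chain carbon bound to a carbonyl carbon. The group that enters, (2,4-dichlorophenyl)sulfanyl, brings the same dichlorinated ring that compound 3 carries on its amide side, where compound 3 gives 16 nM.

Going by the values given here, no step between measured compounds matches this change, so the size must be estimated. Because compound 3 gives 16 nM with a related group, a large drop toward stronger inhibition is expected, a 62-fold lower number from compound 1 to compound 4 (1.79 log units; beyond the scatter). The estimate for compound 4 is 50 nM, with a range from 12 nM to 250 nM.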

Compound 4, inhibition constant: 1500 nM
Compound 4: middle estimate off by 30-fold (1.48 log units), on the low side; measured number above the stated range.
By their numbers in this assay, from the lowest: compounds 2 and 3 (each within the scatter of the next); then compound 4; then compound 1.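

In this assay, (2,4-dichlorophenyl)sulfanyl in place of 4-nitrophenoxy on a saturated chain carbon bound to a carbonyl carbon gives a 2.1-fold lower number from compound 1 to compound 4 (0.32 log units; beyond the scatter), a step that is modest though it lies beyond the scatter. The exchange replaces the linking atom and the ring substituents together, so the step cannot be assigned to either one alone. Nothing measured here accounts for the size of this step.

The compounds shown leave open which part of the exchange produces the step, and 2,4-dichlorophenoxy or (4-nitrophenyl)sulfanyl at this place would separate the two parts. Also open, on these data alone, is how a longer chain between the carbonyl carbon and the sulfur, or an amine in place of the sulfanyl group, would read in this assay.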